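Shortening the side chain of a weak cell-growth inhibitor

The compounds below may be only part of what the source reports. "The series", "measured", "known", "first", "only" and "open" are said of these compounds alone.

The shared core of compound 1 `Cn1cc(C2=C(c3nn(CCCn4cncn4)c4ncccc34)C(=O)NC2=O)c2ccccc21` carries a chain ending in a triazole ring. In a functional assay on SMMC-7721 cells (Homo sapiens) for antiproliferative activity, read by MTT assay, with a stated time of 48 h (a lower number here means a stronger inhibitor, a higher number a weaker inhibitor), compound 1 gives > 100000 nM, which is a limit of the assay rather than a number. Compound 2 `Cn1cc(C2=C(c3nn(CCCN4CCCCC4)c4ncccc34)C(=O)N(c3ccc(Cl)cc3)C2=O)c2ccccc21` shows > 100000 nM in this assay, again only a limit. Both known values therefore sit at the same edge, as the limit of > 100000 nM in this assay, at which 2 of the 2 values shown sit, records, so compound 1 stands no better and no worse than its one companion. Compound 3 `Cn1cc(C2=C(c3nn(CCn4ccnc4)c4ncccc34)C(=O)NC2=O)c2ccccc21` differs from compound 1 by 1H-imidazol-1-yl in place of (1H-1,2,4-triazol-1-yl)methyl on a saturated chain carbon, two bonds along the chain from an aromatic nitrogen. Among the measured compounds shown here, with no measured step available, the change is expected to move potency in this assay by an at least 1.1-fold lower number from compound 1 to compound 3 (0.04 log units; that floor lies within the scatter), that is, no further than the ordinary scatter. Compound 3 is accordingly expected to give about 90000 nM, most likely between 20000 nM and 300000 nM, and quite possibly only another limit.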

Compound 3, half-maximal inhibitory concentration: > 100000 nM
Compound 3 gave a limit, no number (the forecaster's own chance of this, stated with the estimate: 70%); at least 1.1-fold (0.04 log units) between middle value and limit.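

Compound 1 and compound 3 both give only a limit, so the step from one to the other cannot be read: the limit of > 100000 nM in this assay, at which 3 of the 3 values shown sit. The compounds shown leave open whether 1H-imidazol-1-yl and (1H-1,2,4-triazol-1-yl)methyl differ at all in this assay.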